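The compounds below may be only part of what the source reports. "The series", "measured", "known", "first", "only" and "open" are said of these compounds alone.

Working notes on the series.

Compound 1 `CC(C)n1ncc2c(C(=O)NCc3cn(-c4ccc(I)cc4)nn3)cccc21` and compound 2 `COc1ccc(-n2cc(CNC(=O)c3cccc4c3cnn4C(C)C)nn2)cc1` share one core and differ only on the aromatic ring at the triazole nitrogen. In a functional assay on PC-3 cells (Homo sapiens) for inhibition, read by MTT assay, with a stated time of 72 h (a lower number here means a stronger inhibitor, a higher number a weaker inhibitor), compound 1 gives > 40000 nM, which is a limit of the assay and not a number (the limit of > 40000 nM in this assay, at which 1 of the 2 values shown sits). In this assay compound 2 gives 34300 nM, the only number shown in the series. The step of an at least 1.1-fold lower number from compound 1 to compound 2 (0.06 log units; that floor lies within the scatter) therefore tells little, as its floor lies within the scatter.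

Compound 3 `CC(C)n1ncc2c(C(=O)NCc3cn(Cc4ccc(C#N)cc4)nn3)cccc21` differs from compound 2 by 4-cyanobenzyl in place of 4-methoxyphenyl on an aromatic nitrogen. Going by the values given here, no measured step bears on a change of this kind; the one step known, from iodo to methoxy, was at most small. The expected step of a 1.1-fold lower number from compound 2 to compound 3 (0.06 log units; within the scatter) is therefore none beyond the scatter. For compound 3 in this assay the estimate is 30000 nM, with a range from 8000 nM to 100000 nM.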

Compound 3, half-maximal inhibitory concentration: 18200 nM
Compound 3: the middle estimate sits 1.6-fold (0.22 log units) above what was measured; the range from low to high includes it.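

In this assay, 4-cyanobenzyl in place of 4-methoxyphenyl on this aromatic nitrogen gives a 1.9-fold lower number from compound 2 to compound 3 (0.28 log units; within the scatter), so this change does not stand clear of the scatter. Going by these compounds alone, measured against 4-iodophenyl, the same position gives an at least 2.1-fold lower number from compound 1 to compound 3 (0.34 log units; beyond the scatter), the first step whose floor clears the scatter. The value of compound 1 is a limit and not a number, and the step from it is a floor only: the limit of > 40000 nM in this assay, at which 1 of the 3 values shown sits.

On these data alone, compound 3 brings in the benzyl link and the nitrile together, and whether either one alone carries the step stays open; a plain benzyl or a 4-methoxybenzyl group on this nitrogen would bear on that. Also open, as far as these compounds go, is how an amine or a carboxylic acid on the benzyl ring, or a longer chain to that ring, would read in this assay.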